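This account rests on a few compounds, and the source may have more. Where it says the series, first, only, none or still open, it means among the compounds named here.

Measured so far in a functional assay on BT-483 cells (Homo sapiens) for cytotoxicity, read by MTT assay, with a stated time of 24 h; a higher number here means a weaker inhibitor, a lower number a stronger inhibitor:
Compound 1, `CCNc1cc(-c2ccc(NC(=O)Nc3cccc4ccccc34)cc2C)ccn1`, gives > 30000 nM, which is a limit of this assay and not a number.
Compound 2, `CCNc1cc(-c2ccc(NC(=O)Nc3c(C)cccc3C)cc2C)ccn1`, gives > 30000 nM, again a limit.
Compound 3, `CCNc1cc(-c2ccc(NC(=O)Nc3cccc4ccccc34)cc2C(F)(F)F)ccn1`, gives > 30000 nM, also a limit.

From compound 1 to compound 2 the change is 2,6-dimethylphenyl in place of naphthalen-1-yl on an amide-type nitrogen. Its step, a step that the two limits leave unreadable from compound 1 to compound 2, cannot be read because of the limit of > 30000 nM in this assay, at which 3 of the 3 values shown sit. From compound 1 to compound 3 the change is trifluoromethyl in place of methyl on an aromatic carbon, and that step, a step that the two limits leave unreadable from compound 1 to compound 3, is unreadable for the same reason.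

Compound 4, `CCNc1cc(-c2ccc(NC(=O)Nc3c(C)cccc3C)cc2C(F)(F)F)ccn1`, has not been measured. Its difference from compound 3 is 2,6-dimethylphenyl in place of naphthalen-1-yl on an amide-type nitrogen. The place of the change reads the same as for the pair compound 1 and compound 2, while the cores differ by trifluoromethyl in place of methyl on an aromatic carbon, so this is the same kind of change. Since every measured value sits at the limit, the step from compound 3 to compound 4 is expected to be a step that the limit leaves unreadable from compound 3 to compound 4, resting on compound 3 at > 30000 nM. Compound 4 is therefore estimated at 40000 nM in this assay, most likely reported again only as a limit.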

Compound 4, half-maximal inhibitory concentration: 22000 nM
Beside the measured number, compound 4's estimate is 1.8-fold (0.26 log units) above it; the measured number falls inside the stated range.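

On the core of compound 3, 2,6-dimethylphenyl in place of naphthalen-1-yl on the amide-type nitrogen gives an at least 1.3-fold lower number from compound 3 to compound 4 (0.13 log units; that floor lies within the scatter) in this assay, and trifluoromethyl in place of methyl on an aromatic carbon, with 2,6-dimethylphenyl in place, gives an at least 1.3-fold lower number from compound 2 to compound 4 (0.13 log units; that floor lies within the scatter). Both are only floors, so they show that compound 4 has a real number, 22000 nM, but they do not establish a true difference from either partner. The same change on the core of compound 1 and the remaining steps cannot be read, so carrying the change from one core to another stays untested, and the one readable result cannot be called a transfer: the limit of > 30000 nM in this assay, at which 3 of the 4 values shown sit.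

The compounds shown leave open whether the pairing of 2,6-dimethylphenyl with trifluoromethyl matters, as the three limits give no exact partner values for comparison. They also leave open what an amine or a carboxylic acid on the amide-type nitrogen, in place of 2,6-dimethylphenyl, would give in this assay.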